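Working notes: aryl exchange from compound 2 to compound 3

The compounds below may be only part of what the source reports. "The series", "measured", "known", "first", "only" and "open" are said of these compounds alone.

Compound 1 `CC(=O)c1cc2ccc(OCCCn3cc(CNC(=O)CCCCC4CCSS4)nn3)cc2oc1=O` and compound 2 `COc1ccc(-c2cc3ccc(OCCCn4cc(CNC(=O)CCCCC5CCSS5)nn4)cc3oc2=O)cc1` share one core and differ at a single aromatic carbon. In a functional assay on PC-12 cells (Rattus norvegicus) for cytotoxicity, read by MTT assay, with stated times of 3 h and 2 h, tested at 10 uM (a higher number here means a stronger effect of the compound at the concentration tested, a lower number a weaker effect), compound 1 gives 38%, and compound 2 gives 57.6%. Among the compounds with values here, the only measured step, a number 19.6 percentage points higher from compound 1 to compound 2 (beyond the scatter), is all the series shows so far; on it compound 2 stands highest of the two numbers, with compound 1 as its sole neighbour.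

Compound 3 `O=C(CCCCC1CCSS1)NCc1cn(CCCOc2ccc3cc(-c4ccc(Cl)c(Cl)c4)c(=O)oc3c2)nn1` is the next member: 3,4-dichlorophenyl in place of 4-methoxyphenyl on an aromatic carbon. Within the data shown here, no measured step exchanges one aryl group for another; the single step, a number 19.6 percentage points higher from compound 1 to compound 2 (beyond the scatter), concerns acetyl against 4-methoxyphenyl and bears on the change only in that an aryl group sits at the same carbon in both compound 2 and compound 3. On that basis no step beyond the scatter is expected in this assay, the expected step being a number 0.4 percentage points higher from compound 2 to compound 3 (within the scatter). Compound 3 is estimated at 58% in this assay, within a range of 42% to 74%.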

Compound 3, a percentage reported as activity, at one concentration (the size of the read-out at that concentration, not a potency): 49.6%
Estimate against measurement, compound 3: 8.4 percentage points above, within the range that was stated.
By their numbers in this assay, from the lowest: compound 1; then compounds 3 and 2 (each within the scatter of the next).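

In this assay, within the data shown here, the only exchange of one aryl group for another at this aromatic carbon gives a number 8 percentage points lower from compound 2 to compound 3 (within the scatter), so 3,4-dichlorophenyl and 4-methoxyphenyl are not told apart here, although one carries two chlorine atoms and the other an oxygen-linked methyl. Set against acetyl, the second aryl group also clears the scatter, with a number 11.6 percentage points higher from compound 1 to compound 3 (beyond the scatter), so both aryl compounds, compound 2 and compound 3, now separate from compound 1, and neither goes against this. Nothing at hand bears on the reason for either step.

Still open, on these data alone, is whether this separation from acetyl needs an aromatic ring at this carbon at all, which a cyclohexyl group would address. Also open, as far as these compounds go, is whether unsubstituted phenyl, or a phenyl ring carrying an amine or a carboxylic acid, would fall with compound 2 and compound 3.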